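The source may hold more compounds than are shown below. What is called first, only, known or untested is meant among the compounds shown, and "the series" means these compounds.

Measured in a functional assay, read by fluorescence and spectrophotometry, with a stated time of 1 h; on this read-out higher numbers stand for an effect only at larger amounts of compound and lower numbers for an effect already at smaller amounts:
compound 1 `O=S(=O)(/C=C/c1ccc(O)c(O)c1)CCCCCCCO` gives 5900 nM
compound 2 `CCCCCCCCCCCS(=O)(=O)/C=C/c1ccc(O)c(O)c1` gives 11400 nM
compound 3 `CCCCCCCCCS(=O)(=O)/C=C/c1ccc(O)c(O)c1` gives 7700 nM

Compound 1 does not stand apart from the other two, and its nearest neighbour is reached by a 1.3-fold higher number from compound 1 to compound 3 (0.12 log units; within the scatter) as a step. The remaining pair shows a 1.5-fold lower number from compound 2 to compound 3 (0.17 log units; within the scatter) as its step. Compound 4 `O=S(=O)(/C=C/c1ccc(O)c(O)c1)CC1CCCC1` has cyclopentyl in place of 6-hydroxyhexyl on a saturated chain carbon bound to a sulfonyl sulfur. Among the compounds with values here, the measured steps all alter the chain end, and none of the measured compounds carries a ring there, so they bear on this change only in part. The widest is a 1.9-fold higher number from compound 1 to compound 2 (0.29 log units; within the scatter) and stays within the scatter, so no step beyond it is expected in this assay for compound 4. The expected step is a 1.2-fold higher number from compound 1 to compound 4 (0.07 log units; within the scatter) and no larger. For compound 4 the estimated value is 7000 nM with an expected range from 3000 nM to 16000 nM in all.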

Compound 4, half-maximal effective concentration: 9400 nM
Compound 4: the middle estimate sits 1.3-fold (0.13 log units) below what was measured; low and high end bracket the measured number.
By their numbers in this assay, from the lowest: compounds 1, 3, 4 and 2 (each within the scatter of the next).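

Within the data shown here, compound 4 brings a ring to this place for the first time, and in this assay the change gives a 1.6-fold higher number from compound 1 to compound 4 (0.20 log units; within the scatter), so a five-membered non-aromatic ring of carbon only reads no differently here from the 6-hydroxyhexyl chain. The step also removes the hydroxy group with its hydrogen-bond donor and acceptor, and still stays within the scatter. Nothing available explains this result.

Going by these compounds, whether an amine or a carboxylic acid at this place would move the number beyond the scatter remains open. So does the effect of a phenyl ring or a six-membered carbon ring there.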